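Working notes on cytotoxicity in a cyclopentylamino series

The compounds below may be only part of what the source reports. "The series", "measured", "known", "first", "only" and "open" are said of these compounds alone.

Compound 1 `Cc1cc(-c2nc3ccccn3c2NC2CCCC2)ccn1` is the reference point of the set in an ADME assay on THP-1 cells (Homo sapiens) for cytotoxicity; a higher number here means that more compound is tolerated, a lower number that less compound is tolerated. In this assay compound 1 reaches only the limit of the assay, > 50000 nM, and no number. Among the measured compounds shown here, compound 2 `COc1ccc(-c2nc3ccc(C)cn3c2NC2CCCC2)cc1OC` is the only other measured member of the series. In this assay compound 2 likewise stops at the limit, > 50000 nM. For the measured compounds named here, both measured values thus rest at the same bound (the limit of > 50000 nM in this assay, at which 2 of the 2 values shown sit), and no step between two measured compounds can be read off.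

Compound 3 `c1ccn2c(NC3CCCC3)c(-c3nccs3)nc2c1` remains to be measured in this assay. It differs from compound 1 by 1,3-thiazol-2-yl in place of 2-methylpyridin-4-yl on an aromatic carbon. Going by the values given here, with no measured step to lean on, the expected step of a number no higher from compound 1 to compound 3 (the limit leaves the size open) is none beyond the scatter. Compound 3 is therefore estimated at 50000 nM in this assay, with a range from 20000 nM to 120000 nM, most probably again as a limit rather than a number.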

Compound 3, half-maximal cytotoxic concentration: > 50000 nM
Compound 3: only a limit was reported; the forecaster's own chance of this, stated with the estimate: 75%; the middle value sits exactly at the limit.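

No step can be read from compound 1 to compound 3 in this assay, as both values are limits of the assay: the limit of > 50000 nM in this assay, at which 3 of the 3 values shown sit. The compounds shown leave open where the actual half-maximal cytotoxic concentration of each lies, and so whether 1,3-thiazol-2-yl in place of 2-methylpyridin-4-yl changes it at all.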